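The compounds below may be only part of what the source reports. "The series", "measured", "known", "first", "only" and "open" are said of these compounds alone.

Compound 1, `CC#C[C@@H](Cc1nnn[nH]1)c1ccc(OCc2ccc3scc(-c4cccnc4C)c3c2)cc1`: 88 nM in a functional assay on cells for agonist activity at Free fatty acid receptor 1 (Homo sapiens), read by FLIPR and calcium flux; on this read-out higher numbers stand for an effect only at larger amounts of compound and lower numbers for an effect already at smaller amounts.
Compound 2, `CC#C[C@@H](Cc1nnn[nH]1)c1ccc(OCc2ccc3scc(-c4ccc(OCCOC)cc4C)c3c2)cc1`: 9 nM in this assay.

Among the measured compounds shown here, of the two measured numbers, compound 2 has the lowest; the single measured step, a 9.8-fold lower number from compound 1 to compound 2 (0.99 log units; beyond the scatter), separates it from compound 1 and exchanged one aromatic ring for another at the same position.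

Compound 3, `CC#C[C@@H](Cc1nnn[nH]1)c1ccc(OCc2ccc3scc(C4CC4)c3c2)cc1`, differs from compound 2 as follows: cyclopropyl in place of 4-(2-methoxyethoxy)-2-methylphenyl on an aromatic carbon. For the measured compounds named here, only that one step bears on this change, and it shows that the nature of the group at this position shifts the number by a noticeable amount. The change to compound 3 goes further than a swap between two aromatic rings: the whole aromatic ring with its two hydrogen-bond acceptors leaves, and a small three-membered carbon ring enters. A step in the direction of a higher number is therefore expected, plausibly larger than the measured one, though with little to anchor it. Compound 3 is estimated at 150 nM, within a range of 25 nM to 900 nM, which means an expected step of a 17-fold higher number from compound 2 to compound 3 (1.22 log units; beyond the scatter).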

Compound 3, half-maximal effective concentration: 858 nM
Estimate against measurement, compound 3: 5.7-fold (0.76 log units) below, and the stated range covers the measured number.
By their numbers in this assay, from the lowest: compound 2; then compound 1; then compound 3.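

Cyclopropyl on this aromatic carbon gives the highest number of the three in this assay, so this position is sensitive to more than a swap between aromatic rings can reveal. Measured against the larger 4-(2-methoxyethoxy)-2-methylphenyl group, the change gives a 95-fold higher number from compound 2 to compound 3 (1.98 log units; beyond the scatter) and is a large step, while measured against 2-methylpyridin-3-yl it gives a 9.8-fold higher number from compound 1 to compound 3 (0.99 log units; beyond the scatter) and is a modest one. Both steps lie beyond the usual scatter, but nothing measured here accounts for them.

The compounds shown leave open whether the aromatic ring itself or simply a larger group keeps the number low. They also leave open which part of 4-(2-methoxyethoxy)-2-methylphenyl matters, and where a plain phenyl ring, or an amine at the end of the 2-methoxyethoxy chain, would fall.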